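The source may hold more compounds than are shown below. What is called first, only, known or untested is meant among the compounds shown, and "the series" means these compounds.

Compound 2 `Cc1ccc2nc(-c3ccc(N)cc3I)sc2c1` belongs to a pair of compounds that share one core and differ in a single substituent. In a functional assay on MCF7 cells (Homo sapiens) for inhibition (a higher number here means a weaker inhibitor, a lower number a stronger inhibitor), compound 2 gives < 0.1 nM, and that reading is a limit of the assay rather than a number. Compound 1 `Nc1ccc(-c2nc3ccccc3s2)c(I)c1` carries hydrogen where compound 2 carries methyl on an aromatic carbon. In this assay compound 1 gives < 0.1 nM, which is likewise a limit. The step that the two limits leave unreadable from compound 1 to compound 2 therefore cannot be sized, since both readings sit at the limit of < 0.1 nM in this assay, at which 2 of the 2 values shown sit. Compound 3 `COc1ccc2nc(-c3ccc(N)cc3I)sc2c1` is the next variation: methoxy in place of methyl on an aromatic carbon. Among the compounds with values here, the only measured step that touches this position, a step that the two limits leave unreadable from compound 1 to compound 2, is unreadable, so neither a direction nor a size can be drawn from it for this assay, and what remains is that two close relatives both sit at the limit. The expectation for compound 3 is an estimated a number no lower from compound 2 to compound 3 (the limit leaves the size open), meaning no change beyond the scatter. Compound 3 is therefore expected to reach about 0.1 nM, with a range from 0.03 nM to 0.6 nM, most likely reported again as a limit.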

Compound 3, half-maximal inhibitory concentration: < 0.1 nM
Compound 3: no number, only a limit; the forecaster's own chance of this, stated with the estimate: 60%; the middle value sits exactly at the limit.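

In this assay compound 3 gives < 0.1 nM, which is again a limit and not a number. Within the data shown here, no step among compound 1, compound 2 and compound 3 can be read: the limit of < 0.1 nM in this assay, at which 3 of the 3 values shown sit. The compounds shown leave open whether hydrogen, methyl and methoxy on this aromatic carbon differ in inhibition at all, and by how much.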